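A Bromine-to-Trifluoromethyl Swap and an Expected Potency

The compounds below may be only part of what the source reports. "The series", "measured", "known", "first", "only" and "open" are said of these compounds alone.

Compound 1 `CCOc1ccc(C(=O)/C=C/c2ccc(Br)cc2)cc1` is the reference point here. In an assay on isolated protein for inhibition of Amine oxidase [flavin-containing] B (Homo sapiens) (on this read-out higher numbers stand for weaker inhibition and lower numbers for stronger inhibition), compound 1 gives 210 nM, the lowest of the two plain numbers shown. Compound 3 `CCc1ccc(/C=C/C(=O)c2ccc(-n3ccnc3)cc2)cc1` gives 320 nM in this assay, a number that stands within the usual scatter of the value for compound 1. Compound 2 `COc1ccc(C(=O)/C=C/c2ccc(O/N=C(\C)c3ccccc3)cc2)cc1` gives only a limit of the assay, > 200 nM, the one noted in the limit of > 200 nM in this assay, at which 1 of the 3 values shown sits. Compound 4 `CCOc1ccc(C(=O)/C=C/c2ccc(C(F)(F)F)cc2)cc1` differs from compound 1 by a single change: trifluoromethyl in place of bromo on an aromatic carbon. Among the compounds with values here, no measured pair shows a step of this kind, so the expectation rests on compound 1 alone. The change is expected to move the number little, if at all beyond the scatter, which means an expected step of a 1.4-fold higher number from compound 1 to compound 4 (0.15 log units; within the scatter). Compound 4 is therefore estimated at 300 nM, with a range from 100 nM to 900 nM.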

Compound 4, half-maximal inhibitory concentration: 210 nM
Compound 4: the middle estimate sits 1.4-fold (0.15 log units) above what was measured; the measured number falls inside the stated range.
By their numbers in this assay, from the lowest: compounds 1, 4 and 3 (each within the scatter of the next).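

Trifluoromethyl in place of bromo on an aromatic carbon gives the first single-place comparison here, with no change at the digits printed from compound 1 to compound 4 (within the scatter) in this assay. At this position, para to a large group, a group of 4 heavy atoms thus reads the same as a group of 1 heavy atom, so this read-out does not separate the two. Nothing shown explains why they read alike.

Only these two groups can be compared at this position. On these data alone, how an amine, a carboxylic acid or a longer chain would read there remains open.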